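Removing the butyl from the sulfonamide on a second core

A few compounds are considered here, and "the series" means these few. Any claim that something is new, unique, unknown or untested is made for them only; others in the source may bear on it.

Measured so far in an assay for inhibition of serine/threonine-protein kinase PLK2 (Homo sapiens), read by FRET and Z'-LYTE, with a stated time of 1 h; a higher number here means a weaker inhibitor, a lower number a stronger inhibitor:
compound 1, `CCCCNS(=O)(=O)c1ccc(Nc2ncc3c(n2)N(C2CCCC2)[C@H](CC)C(=O)N3C)cc1`, gives 19.9 nM;
compound 2, `CCCCNS(=O)(=O)c1ccc(Nc2ncc3c(n2)N(c2ccn(C)n2)C(CC)C(=O)N3C)cc1`, gives 191 nM;
compound 3, `CC[C@@H]1C(=O)N(C)c2cnc(Nc3ccc(S(N)(=O)=O)cc3)nc2N1C1CCCC1`, gives 10.2 nM.

Compounds 1 and 3 share one core and differ in a single place: hydrogen in place of butyl on a sulfonamide nitrogen. That change made a step of a 2.0-fold lower number from compound 1 to compound 3 (0.29 log units; within the scatter), so on this core the two sulfonamides give numbers that cannot be told apart. Compound 2 carries a different core; how its core differs from that of compound 1 is not broken down here. What the values show is that compound 2 gives the highest number of the three in this assay, and that compound 1 stands nearer to it than compound 3 does.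

Compound 4, `CCC1C(=O)N(C)c2cnc(Nc3ccc(S(N)(=O)=O)cc3)nc2N1c1ccn(C)n1`, is not yet measured. It relates to compound 2 exactly as compound 3 relates to compound 1: hydrogen in place of butyl on a sulfonamide nitrogen. Since the same change is made on a second core, compound 4 is expected to follow the step seen from compound 1 to compound 3, giving an estimated step of a 1.7-fold lower number from compound 2 to compound 4 (0.24 log units; within the scatter), with its size resting on a 2.0-fold lower number from compound 1 to compound 3 (0.29 log units; within the scatter). Compound 4 is therefore estimated to give 110 nM in this assay, expected to lie between 45 nM and 270 nM.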

Compound 4, half-maximal inhibitory concentration: 121 nM
Beside the measured number, compound 4's estimate is 1.1-fold (0.04 log units) below it, within the range that was stated.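

In this assay, hydrogen in place of butyl on a sulfonamide nitrogen gives a 1.6-fold lower number from compound 2 to compound 4 (0.20 log units; within the scatter), so on this second core, as on the first, the two sulfonamides give numbers that cannot be told apart. Set side by side, the two steps show that the change carries from one core to the other without a difference that can be read: the same change on two cores in this assay, a 2.0-fold lower number (0.29 log units; within the scatter) from compound 1 to compound 3 and a 1.6-fold lower number (0.20 log units; within the scatter) from compound 2 to compound 4, 1.2-fold (0.09 log units) apart, within the scatter of two such steps This shows only that butyl and hydrogen at this place are not told apart on these two cores; it does not fix the true size of either step, since both lie within the scatter, and it does not extend to any other core in the series.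

The compounds shown leave open whether a group other than butyl on the sulfonamide nitrogen, such as a longer chain, a chain ending in an amine or one ending in a carboxylic acid, would also leave the number unchanged. They also leave open whether such a group would behave alike on both cores.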